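Trisubstituted thiazoles against Jurkat cell growth

The source may report more compounds than this note shows. Statements on the series, on what has been measured and on what is new or still open speak of the compounds shown alone.

Compound 1 `CNc1nc(-c2cc(OC)c(OC)c(OC)c2)c(-c2ccc(C(F)(F)F)cc2)s1`: 3010 nM
Compound 2 `CNc1nc(-c2cc(OC)c(OC)c(OC)c2)c(-c2ccc(OC)cc2)s1`: 34.3 nM
Compound 3 `COc1cc(-c2nc(N(C)C)sc2-c2ccc(C(F)(F)F)cc2)cc(OC)c1OC`: > 10000 nM

Three compounds on a shared core were run in a functional assay on Jurkat cells (Homo sapiens) for antiproliferative activity, read by MTT assay, with a stated time of 72 h; a lower number here means a stronger inhibitor, a higher number a weaker inhibitor. Compound 1 gives 3010 nM. Compound 2, which carries methoxy in place of trifluoromethyl on an aromatic carbon, gives 34.3 nM. The change brings an 88-fold lower number from compound 1 to compound 2 (1.94 log units; beyond the scatter). Compound 3 differs from compound 1 by methyl in place of hydrogen on a nitrogen on an aromatic ring. Compound 3 gives > 10000 nM, which is a limit of the assay and not a number. That change brings an at least 3.3-fold higher number from compound 1 to compound 3 (0.52 log units; beyond the scatter), a step that can only be bounded because of the limit of > 10000 nM in this assay, at which 1 of the 3 values shown sits.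

Compound 4 `COc1ccc(-c2sc(N(C)C)nc2-c2cc(OC)c(OC)c(OC)c2)cc1` has not yet been measured in this assay. It differs from compound 3 by methoxy in place of trifluoromethyl on an aromatic carbon. The place of this change is the same, word for word, as that of the change from compound 1 to compound 2, so it is the same change made on a different core; how the two cores differ is given by methyl in place of hydrogen on a nitrogen on an aromatic ring. Because the earlier change gave an 88-fold lower number from compound 1 to compound 2 (1.94 log units; beyond the scatter), a large step in the same direction is expected here too, read off a limit rather than a number for compound 3. Compound 4 is accordingly expected to show an at least 50-fold lower number from compound 3 to compound 4 (1.69 log units; beyond the scatter). Compound 4 is estimated at 200 nM, between 50 nM and 1500 nM.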

Compound 4, half-maximal inhibitory concentration: 7600 nM
Compound 4: the middle estimate sits 38-fold (1.58 log units) below what was measured; the measured number lies above the stated range.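

In this assay, going from 4-(trifluoromethyl)phenyl to 4-methoxyphenyl on the core of compound 3 gives an at least 1.3-fold lower number from compound 3 to compound 4 (0.11 log units; that floor lies within the scatter), so the series neither shows that the large drop seen on the core of compound 1 carries over to this core nor shows that it fails to: the same change on two cores in this assay, an 88-fold lower number (1.94 log units; beyond the scatter) from compound 1 to compound 2 and an at least 1.3-fold lower number (0.11 log units; that floor lies within the scatter) from compound 3 to compound 4; the limit leaves it open whether they differ

Compound 3 stands at > 10000 nM, which is a limit of the assay and not a number.

Methyl in place of hydrogen on the nitrogen gives a 220-fold higher number from compound 2 to compound 4 (2.35 log units; beyond the scatter) among the methoxy compounds, while among the trifluoromethyl compounds the same change can only be bounded, so a single size for this change across the two cores is neither established nor ruled out: the same change on two cores in this assay, an at least 3.3-fold higher number (0.52 log units; beyond the scatter) from compound 1 to compound 3 and a 220-fold higher number (2.35 log units; beyond the scatter) from compound 2 to compound 4; the limit leaves it open whether they differ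

The compounds shown leave open how a free amine or a longer chain such as ethyl on that nitrogen would read in this assay, and so whether the loss tracks the second methyl specifically. They also leave open whether a group such as chlorine or hydroxyl in place of methoxy would behave as methoxy does on both cores, which a measured number for a trifluoromethyl compound on the core of compound 3 would help to settle.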